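Aryl swap at the benzylic carbon, compound 3 to 4

This account rests on a few compounds, and the source may have more. Where it says the series, first, only, none or still open, it means among the compounds named here.

Measured compounds in a functional assay on CCRF-CEM cells (Homo sapiens) for antiproliferative activity, with a stated time of 72 h; on this read-out higher numbers stand for weaker inhibition and lower numbers for stronger inhibition
Compound 1 `OC[C@H]1O[C@@H](n2cnc3c(NCc4cccc(F)c4)ncnc32)[C@H](O)[C@@H]1O` gives 4000 nM
Compound 2 `OC[C@H]1O[C@@H](n2cnc3c(NCc4ccc(Cl)cc4)ncnc32)[C@H](O)[C@@H]1O` gives 10200 nM
Compound 3 `OC[C@H]1O[C@@H](n2cnc3c(NCc4cc(O)cc(O)c4)ncnc32)[C@H](O)[C@@H]1O` gives "not determined" (no result reported)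

Compound 3 has no number, so no measured starting point exists for this step. Compound 4 `Cc1cccc(CNc2ncnc3c2ncn3[C@@H]2O[C@H](CO)[C@@H](O)[C@H]2O)c1O` carries 2-hydroxy-3-methylphenyl in place of 3,5-dihydroxyphenyl on a saturated chain carbon bound to a nitrogen on an aromatic ring. Among the compounds with values here, the only measured step that bears on it is a 2.6-fold higher number from compound 1 to compound 2 (0.41 log units; beyond the scatter) and it swaps other groups at that place, so it offers a rough guide to scale only. No size or direction of step can therefore be expected in this assay from compound 3. Compound 4 is expected at 5000 nM within an estimated range from 800 nM to 25000 nM on this read-out.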

Compound 4, half-maximal inhibitory concentration: 900 nM
Compound 4: middle estimate off by 5.6-fold (0.74 log units), on the high side, and the stated range covers the measured number.
By their numbers in this assay, from the lowest: compound 4; then compound 1; then compound 2.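

In this assay the phenyl substituent at this place matters more than the earlier pair suggested: 2-hydroxy-3-methylphenyl gives an 11-fold lower number from compound 2 to compound 4 (1.05 log units; beyond the scatter) and a 4.4-fold lower number from compound 1 to compound 4 (0.65 log units; beyond the scatter) in the same series, leaving compound 4 the most potent of the three compounds with numbers. The step from compound 3 cannot be read, as compound 3 has no number. No measurement here explains the gain.

Open, on these data alone, is whether the hydroxy or the methyl group of 2-hydroxy-3-methylphenyl accounts for the lower number. Also open, as far as these compounds go, is how an amine or a carboxylic acid on the phenyl ring would behave.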